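Replacing Oxetane with Pyridine on an Amide Nitrogen

The compounds below may be only part of what the source reports. "The series", "measured", "known", "first", "only" and "open" are said of these compounds alone.

Compound 1 `Cc1ccc(OCC(=O)N(Cc2cccs2)C2COC2)cc1` carries an oxetan-3-yl group on its amide-type nitrogen. Among the measured compounds shown here, in an assay on HEK293 cells for agonist activity at transient receptor potential cation channel subfamily M member 8 (Homo sapiens), read by fluorescence and calcium flux, with a stated time of 15 min (a higher number here means that more compound is needed for the effect, a lower number that less compound is needed), compound 1 gives 23000 nM, the highest of the two numbers measured so far. Compound 2 `CCN(Cc1cccs1)C(=O)COc1ccc(Cl)cc1`, which carries a small chain on the same kind of nitrogen and a chloro group on its outer ring, gives 39 nM in this assay, a far lower number that lies well beyond the scatter. Compound 3 `CCN(Cc1cn[nH]c1)C(=O)COc1ccc(C)cc1` is reported in this assay only as "active" (no number reported), with no number given.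

Compound 4 `Cc1ccc(OCC(=O)N(Cc2cccs2)c2ccccn2)cc1` differs from compound 1 in one place: pyridin-2-yl in place of oxetan-3-yl on an amide-type nitrogen. For the measured compounds named here, no measured pair shows this change directly, so its effect can only be guessed. Because compound 1 gives 23000 nM while compound 2 gives 39 nM, the amide-type nitrogen appears to be a place where the substituent matters a great deal, and a step in the lower direction is expected, though of uncertain size. The step of a 5.8-fold lower number from compound 1 to compound 4 (0.76 log units; beyond the scatter) is the expected size. Compound 4 is expected to give 4000 nM, within a range from 500 nM to 30000 nM.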

Compound 4, half-maximal effective concentration: 200 nM
Compound 4: middle estimate off by 20-fold (1.30 log units), on the high side, outside the stated range (below it).
By their numbers in this assay, from the lowest: compound 2; then compound 4; then compound 1.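

With the rest of the structure unchanged, pyridin-2-yl in place of oxetan-3-yl on the amide-type nitrogen gives a 120-fold lower number from compound 1 to compound 4 (2.06 log units; beyond the scatter) in this assay, the first direct sign that this substituent alone can shift the number by a large amount. The earlier gap at this nitrogen could not show this, as the compounds compared there also differed on the outer ring. The two groups have the same hydrogen-bond donor and acceptor counts and no net charge, but they differ in ring size and aromatic character, and no measurement shown here explains the fall.

On these data alone, it remains open whether the ring nitrogen of pyridin-2-yl matters or whether an aromatic ring alone is enough, a question that a plain phenyl group at this place would help to settle. As far as these compounds go, the effect of a saturated six-membered ring such as tetrahydropyranyl also remains open.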